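The source may report more compounds than this note shows. Statements on the series, on what has been measured and on what is new or still open speak of the compounds shown alone.

Compound 2 `CCOC/C=C/c1ccc(CN(C(=O)C2CCCCC2)c2cccc(/C=C/C(=O)OC)c2)cc1` is the point of departure. For the measured compounds named here, in an assay on isolated protein with Bile acid receptor (Homo sapiens) as the target (a higher number here means that more compound is needed for the effect, a lower number that less compound is needed), compound 2 gives 198000 nM, which is the only number among the two values shown for this target. Compound 1 `CCOC(=O)/C=C/c1ccc(CN(C(=O)C2CCCCC2)c2cccc(/C=C/C(=O)OC)c2)cc1` is its nearest relative, carrying ethoxycarbonyl where compound 2 carries ethoxymethyl on a double-bonded chain carbon bound to a double-bonded chain carbon. In this assay compound 1 returns only a limit of the assay, > 1000 nM. The step that the limit leaves unreadable from compound 1 to compound 2 can therefore not be sized, because the limit of > 1000 nM in this assay, at which 1 of the 2 values shown sits, hides its starting point. Compound 3 `COC(=O)/C=C/c1cccc(N(Cc2ccc(/C=C/c3ccc(OC)cc3)cc2)C(=O)C2CCCCC2)c1` has not yet been measured. It differs from compound 2 in one place: 4-methoxyphenyl in place of ethoxymethyl on a double-bonded chain carbon bound to a double-bonded chain carbon. No measured step bears on this change; the single step shown is unreadable and concerns a different group, so the expectation rests on compound 2 alone and on the weak 198000 nM it gives. Compound 3 is expected to give about 40000 nM in this assay, with a wide range from 3000 nM to 200000 nM. The estimated step of a 5.0-fold lower number from compound 2 to compound 3 (0.69 log units; beyond the scatter) leans toward less compound being needed, but the uncertainty is large.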

Compound 3, half-maximal effective concentration: 208 nM
Beside the measured number, compound 3's estimate is 190-fold (2.28 log units) above it; the whole stated range lies above it.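

At the place on a double-bonded chain carbon bound to a double-bonded chain carbon, the earlier pair gave no readable step, and this change supplies the first size: in this assay, 4-methoxyphenyl in place of ethoxymethyl brings a 950-fold lower number from compound 2 to compound 3 (2.98 log units; beyond the scatter), so with the rest of the molecule unchanged, the group at this place can shift the number very strongly. Set against ethoxycarbonyl, the same 4-methoxyphenyl gives an at least 4.8-fold lower number from compound 1 to compound 3 (0.68 log units; beyond the scatter), and this figure is only a bound on the true size because of the limit at its starting end: the limit of > 1000 nM in this assay, at which 1 of the 3 values shown sits. Compound 1 gives only a limit of the assay, > 1000 nM, so the step to compound 2 still cannot be read, and ethoxycarbonyl and ethoxymethyl cannot be ranked against each other.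

From the compounds shown here alone, it remains open whether the large step belongs to the aromatic ring itself or to its methoxy group, a question that a plain phenyl or a 4-hydroxyphenyl at this place would address. Going by these compounds, it is also open whether 4-methoxyphenyl would give a step of similar size with a carboxylic acid in place of the methyl ester that all three compounds share.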